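The source may hold more compounds than are shown below. What is called first, only, known or untested is meant among the compounds shown, and "the series" means these compounds.

Working notes on the series. In an ADME assay on MT4 cells (Homo sapiens) for cytotoxicity, read by MTT assay, with a stated time of 4 days (on this read-out lower numbers stand for higher toxicity in this test and higher numbers for lower toxicity in this test), compound 1 (`Cc1ccc(NC(=O)CS(=O)(=O)c2nccc(Oc3c(C)cc(C#N)cc3C)n2)cc1`) gives 7490 nM and compound 2 (`COc1ccc(NC(=O)CS(=O)(=O)c2nccc(Oc3c(C)cc(C#N)cc3C)n2)cc1`) gives 5110 nM. As far as these compounds go, compound 3 (`Cc1cc(C#N)cc(C)c1Oc1ccnc(S(=O)(=O)CC(=O)Nc2ccc(C#N)cc2)n1`) is reported only as a limit, >= 6010 nM, so its exact place on the scale is unknown. The measured steps to it are a step that the limit leaves unreadable from compound 1 to compound 3 and an at least 1.1-fold higher number from compound 2 to compound 3 (0.07 log units; that floor lies within the scatter).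

Compound 4 (`Cc1cc(C#N)cc(C)c1Oc1ccnc(S(=O)(=O)CC(=O)Nc2ccc(C#N)cc2F)n1`) carries fluoro in place of hydrogen on an aromatic carbon, ortho to a large group and meta to a cyano group: fluoro in place of hydrogen on an aromatic carbon. For the measured compounds named here, no measured step tests this exact change. The nearest evidence is the group swaps on the same ring, and the only fully readable one is a 1.5-fold lower number from compound 1 to compound 2 (0.17 log units; within the scatter). On that basis, no step beyond the scatter is expected in this assay. The expected step is a step that the limit leaves unreadable from compound 3 to compound 4. For compound 4 the estimated value is 6500 nM, with an expected range of 3000 nM to 14000 nM.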

Compound 4, half-maximal cytotoxic concentration: > 268000 nM
Compound 4 gave a limit, no number (the forecaster's own chance of this, stated with the estimate: 40%); middle value at least 41-fold (1.61 log units) from the limit.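

In this assay compound 4 is reported only as a limit, > 268000 nM. With 4-cyano-2-fluorophenyl on the amide-type nitrogen, the series shows its first steps beyond the scatter: an at least 52-fold higher number from compound 2 to compound 4 (1.71 log units; beyond the scatter) and an at least 35-fold higher number from compound 1 to compound 4 (1.55 log units; beyond the scatter), both large. The step that isolates fluoro in place of hydrogen, between compound 3 and compound 4, cannot be read, as both values are limits, so these large steps show the effect of the whole group swap and not of the fluoro alone.

As far as these compounds go, how much of the gap belongs to the fluoro and how much to the cyano group therefore stays open. Also open, from the compounds shown here alone, is whether a chloro or an amino group on the same aromatic carbon, ortho to a large group, would give a value of the same order in this assay.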